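The source may report more compounds than this note shows. Statements on the series, on what has been measured and on what is new or still open speak of the compounds shown alone.

Measured in a functional assay on the whole organism for activation, with Mus musculus as the target; on this read-out lower numbers stand for an effect already at smaller amounts and higher numbers for an effect only at larger amounts of compound:
- Compound 1 `CCCCCCCCc1ccc2c(c1)CC[C@H]([C@](C)(N)CO)C2`: > 5 mg/kg (a limit of the assay)
- Compound 2 `CCCCCCCCc1ccc2c(c1)CC[C@@H](C(N)(CO)CO)C2`: 0.2 mg/kg

Among the measured compounds shown here, compound 2 holds the only actual number so far, at 0.2 mg/kg. For the measured compounds named here, the single other result is the one for compound 1, and it is a limit rather than a number.

The next compound to be tested is compound 3 `CCCCCCCCc1ccc2c(c1)CC[C@@H]([C@](C)(N)CO)C2`. It keeps the shared core of compound 2 but carries 1-amino-1-(hydroxymethyl)ethyl in place of 1-amino-2-hydroxy-1-(hydroxymethyl)ethyl on a saturated ring carbon.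

Going by the values given here, no measured pair shows what this exchange does in this assay, so the expectation is loose. No step beyond the usual scatter is expected, with a slight lean towards a higher dose, and the range is left wide on that upper side. The expected change is a 1.5-fold higher number from compound 2 to compound 3 (0.18 log units; within the scatter). For compound 3 the estimated value is 0.3 mg/kg, with an expected range from 0.05 mg/kg to 3 mg/kg.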

Compound 3, dose for half-maximal effect: > 5 mg/kg
Compound 3: only a limit was reported (the forecaster's own chance of this, stated with the estimate: 20%); middle value at least 16-fold (1.22 log units) from the limit.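

In this assay, among the compounds shown here, the exchange of 1-amino-2-hydroxy-1-(hydroxymethyl)ethyl for 1-amino-1-(hydroxymethyl)ethyl on a saturated ring carbon gives an at least 25-fold higher number from compound 2 to compound 3 (1.39 log units; beyond the scatter), the first reading of this change and a large one. The result for compound 3 is a limit and not a number, and it is the same limit that compound 1 reached: the limit of > 5 mg/kg in this assay, at which 2 of the 3 values shown sit. Both results being limits, the steps between them cannot be read, so this pair ranks neither drawn configuration at the saturated ring carbon, and the comparison rests on one point: the fact that compounds 1 and 3 differ only in the configuration as drawn

As far as these compounds go, how far compound 1 and compound 3 lie beyond the limit remains open, as does the effect of the opposite configuration at the stereocentre that enters with 1-amino-1-(hydroxymethyl)ethyl. Also open, from the compounds shown here alone, is whether an aminomethyl group or a carboxylic acid in place of the hydroxymethyl lost in this change would restore a value like that of compound 2, 0.2 mg/kg, in this assay.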